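One added hydroxy on compound 1

This account rests on a few compounds, and the source may have more. Where it says the series, first, only, none or still open, it means among the compounds named here.

Values measured so far in a functional assay on microsomes for inhibition, with a stated time of 1 h (on this read-out lower numbers stand for stronger inhibition and higher numbers for weaker inhibition), are these.

compound 1 `CSc1nc(-c2ccccc2O)c(C#N)c(=O)n1C` gives 44 ug/mL
compound 2 `CCOC(=O)c1cnn(-c2nc(-c3ccco3)c(C#N)c(=O)n2C)c1N` gives 116 ug/mL
compound 3 `Cn1c(NN)nc(-c2ccccc2O)c(C#N)c1=O` gives 34 ug/mL

Compound 1 stands in the lower pair of these numbers. The measured step of a 1.3-fold lower number from compound 1 to compound 3 (0.11 log units; within the scatter) lies within the scatter, so that pair cannot be separated. Compound 2 at 116 ug/mL sits clearly higher, which means weaker inhibition, than compound 1 at 44 ug/mL.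

Compound 4 `CSc1nc(-c2cccc(O)c2O)c(C#N)c(=O)n1C` has not yet been measured. It is compound 1 with one change (hydroxy in place of hydrogen on an aromatic carbon), hydroxy in place of hydrogen on an aromatic carbon, ortho to a hydroxy group and meta to a large group.

For the measured compounds named here, only one measured step bears on this, and only loosely. The step of a 1.3-fold lower number from compound 1 to compound 3 (0.11 log units; within the scatter) swaps methylsulfanyl for aminoamino, a different change, and it stayed within the scatter. Compound 2 differs from compound 1 in more than one place, so it isolates no single change. Going by the values given here, no measurement yet tests an added hydroxy. No step beyond the scatter is therefore expected in this assay, and no firm direction can be called. The estimate amounts to an expected step of a 1.2-fold lower number from compound 1 to compound 4 (0.06 log units; within the scatter). For compound 4 the estimated value is 38 ug/mL, with an expected range of 14 ug/mL to 100 ug/mL.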

Compound 4, half-maximal inhibitory concentration: 41 ug/mL
Beside the measured number, compound 4's estimate is 1.1-fold (0.03 log units) below it; measured number inside the range.
By their numbers in this assay, from the lowest: compounds 3, 4 and 1 (each within the scatter of the next); then compound 2.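

In this assay, placing a hydroxy on this aromatic carbon, ortho to a hydroxy group and meta to a large group, gives a 1.1-fold lower number from compound 1 to compound 4 (0.03 log units; within the scatter), so compound 1 and compound 4 cannot be told apart. For the compounds shown here, this is the first direct look at this position, and it shows that the added oxygen, with its hydrogen-bond donor and acceptor, brings no change in inhibition that can be separated from the usual scatter on this read-out. No measurement at hand explains this outcome.

One hydroxy cannot show how much this position accepts: a methoxy, an amine, a carboxylic acid or a longer chain on the same carbon could give a quite different number. On these data alone, it also remains open whether the same hydroxy would give a similarly small step on compound 3, which carries aminoamino in place of methylsulfanyl, and what removing the hydroxy already present on compound 1 would do to inhibition.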